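Chloro on the Benzoyl Ring: Expected Cytotoxicity of Compound 3

The source may report more compounds than this note shows. Statements on the series, on what has been measured and on what is new or still open speak of the compounds shown alone.

Compound 1, `O=C(CN1CCN(C(=O)c2ccccc2)CC1)N1CCN(CCCc2c[nH]c3ccccc23)CC1`, in an ADME assay on HEK293 cells (Homo sapiens) for cytotoxicity, read by MTT assay, with a stated time of 72 h (on this read-out lower numbers stand for stronger inhibition and higher numbers for weaker inhibition), gives > 200000 nM, which is a limit of the assay rather than a number.
Compound 2, `O=C(CN1CCN(C(=O)c2ccccc2)CC1)N1CCN(CCCc2c[nH]c3ccc(F)cc23)CC1`, in this assay gives 148000 nM.

For the measured compounds named here, compound 2 thus carries the only number in this set; the one other value shown is a limit. The measured step of an at least 1.3-fold lower number from compound 1 to compound 2 (0.13 log units; that floor lies within the scatter) rests on fluoro in place of hydrogen on an aromatic carbon, and because one of the two values sits at the limit of > 200000 nM in this assay, at which 1 of the 2 values shown sits, its true size is open and its floor lies within the scatter.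

Compound 3, `O=C(CN1CCN(C(=O)c2cccc(Cl)c2)CC1)N1CCN(CCCc2c[nH]c3ccc(F)cc23)CC1`, differs from compound 2 by chloro in place of hydrogen on an aromatic carbon on the benzoyl group, meta to a large group. Going by the values given here, no measured step touches that ring; the only step recorded, from compound 1 to compound 2, is small and sits on the other end of the molecule. Without bearing evidence, no shift beyond the scatter is expected in this assay. Compound 3 is therefore expected to give 120000 nM, within 50000 nM to 200000 nM. The step this estimate implies is a 1.2-fold lower number from compound 2 to compound 3 (0.09 log units; within the scatter), expected to stay within the scatter, with a fair chance that only a limit is reported.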

Compound 3, half-maximal inhibitory concentration: 66200 nM
For compound 3 the middle estimate is 1.8-fold (0.26 log units) above the measured one; the range from low to high includes it.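

A chloro entering on the benzoyl group, meta to a large group, gives a 2.2-fold lower number from compound 2 to compound 3 (0.35 log units; beyond the scatter) in this assay, so the benzoyl end of the molecule does respond in this read-out. For the compounds shown here, this is the only step in the set with a full size that lies beyond the scatter; the earlier step, on the other end of the molecule, has only a floor, and that floor lies within the scatter. The step is modest, and it takes only the change from phenyl to 3-chlorophenyl: one chlorine atom enters, with no ring, no hydrogen-bond donor or acceptor and no net charge.

What a methoxy group, a nitrile or an amine would do at this place stays open, as does whether the chloro step would carry over to the core of compound 1, which lacks the fluoro, and nothing shown gives a cause for the step. Compound 1 stands at a limit, so the size of the fluoro step also stays open, and the two steps cannot be set against each other: the limit of > 200000 nM in this assay, at which 1 of the 3 values shown sits.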